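Swapping the amide aryl group: dimethoxy for difluoro

A few compounds are considered here, and "the series" means these few. Any claim that something is new, unique, unknown or untested is made for them only; others in the source may bear on it.

Measured so far in a functional assay on HepG2 cells (Homo sapiens) for antiproliferative activity, read by CCK-8 assay, with a stated time of 72 h; on this read-out lower numbers stand for stronger inhibition and higher numbers for weaker inhibition:
- compound 1 `COc1ccc(C(=O)Nc2ccc(C(=O)/C=C/c3nc(C)c(C)nc3C)cc2)cc1OC` gives 2560 nM
- compound 2 `Cc1nc(C)c(/C=C/C(=O)c2ccc(NC(=O)c3ccc(F)cc3)cc2)nc1C` gives 2250 nM
- compound 3 `Cc1nc(C)c(/C=C/C(=O)c2ccc(NC(=O)c3ccc(F)cc3F)cc2)nc1C` gives 2990 nM

All three share the same core and differ only in the aryl group attached to the amide carbonyl. Compound 3 has the highest number of the three, yet its steps to the others are small: a 1.2-fold higher number from compound 1 to compound 3 (0.07 log units; within the scatter) and a 1.3-fold higher number from compound 2 to compound 3 (0.12 log units; within the scatter) both sit inside the scatter, so no real ordering can be read from them. The same holds for a 1.1-fold lower number from compound 1 to compound 2 (0.06 log units; within the scatter).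

Compound 4 `COc1cc(OC)cc(C(=O)Nc2ccc(C(=O)/C=C/c3nc(C)c(C)nc3C)cc2)c1` is the next variation on this pattern: 3,5-dimethoxyphenyl in place of 2,4-difluorophenyl on a carbonyl carbon. The closest guide is compound 1, which already carries two methoxy groups on that ring and whose number stands within the scatter of compound 3. Every step measured so far at this position has stayed within the scatter, so for compound 4 the expectation in this assay is likewise no change beyond the scatter, a 1.1-fold lower number from compound 3 to compound 4 (0.04 log units; within the scatter). The estimated value for compound 4 is 2700 nM, with a range from 1200 nM to 6000 nM.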

Compound 4, half-maximal inhibitory concentration: 11000 nM
For compound 4 the middle estimate is 4.1-fold (0.61 log units) below the measured one; the whole stated range lies below it.
By their numbers in this assay, from the lowest: compounds 2, 1 and 3 (each within the scatter of the next); then compound 4.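

Unlike the earlier swaps at this position, the change to 3,5-dimethoxyphenyl moves the number beyond the scatter: this assay shows a 3.7-fold higher number from compound 3 to compound 4 (0.57 log units; beyond the scatter) and a 4.9-fold higher number from compound 2 to compound 4 (0.69 log units; beyond the scatter) for the same kind of swap. The comparison with the other dimethoxy compound is the most telling, since 3,5-dimethoxyphenyl in place of 3,4-dimethoxyphenyl gives a 4.3-fold higher number from compound 1 to compound 4 (0.63 log units; beyond the scatter) with the same two methoxy groups on the ring, so the arrangement of those groups matters here and not just their presence. No measurement available here explains this difference.

From the compounds shown here alone, it remains open whether the weaker result follows the arrangement of the groups in 3,5-dimethoxyphenyl itself or needs methoxy groups in particular, which a ring carrying two fluoro groups in that same arrangement could help to separate. How a ring carrying an amine or a carboxylic acid would behave at this position is also unknown.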